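The source may hold more compounds than are shown below. What is called first, only, known or untested is meant among the compounds shown, and "the series" means these compounds.

In an assay on CHO cells for positive allosteric modulation of metabotropic glutamate receptor 5 (Homo sapiens), read by FLIPR (a higher number here means that more compound is needed for the effect, a lower number that less compound is needed), compound 3 `O=C(Nc1ccc(Cl)cc1CN1C(=O)c2ccccc2C1=O)c1cncs1` gives 1900 nM, the lowest of the three numbers recorded. Compound 1 `O=C(Nc1ccc(Cl)cc1CN1C(=O)c2ccccc2C1=O)c1ccccc1[N+](=O)[O-]` gives 5700 nM, and compound 2 `O=C(Nc1ccc(Cl)cc1CN1C(=O)c2ccccc2C1=O)c1cccnc1` gives 35000 nM. Two steps lead to compound 3: a 3.0-fold lower number from compound 1 to compound 3 (0.48 log units; beyond the scatter) and an 18-fold lower number from compound 2 to compound 3 (1.27 log units; beyond the scatter). Compound 4 `O=C(Nc1ccc(Cl)cc1CN1C(=O)c2ccccc2C1=O)c1cccnn1` differs from compound 3 by pyridazin-3-yl in place of 1,3-thiazol-5-yl on a carbonyl carbon. Within the data shown here, no measured step covers this exact change; the nearest guide is an 18-fold lower number from compound 2 to compound 3 (1.27 log units; beyond the scatter), where a six-membered aromatic ring gave way to a five-membered one. Returning to a six-membered ring is therefore expected to raise the number in this assay, though the change is not the same one, so its size is uncertain. For compound 4 the step is estimated as a 4.7-fold higher number from compound 3 to compound 4 (0.68 log units; beyond the scatter). Compound 4 is thus expected at 9000 nM, within 2500 nM to 32000 nM.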

Compound 4, half-maximal effective concentration: > 100000 nM
Compound 4: a limit, no number; the forecaster's own chance of this, stated with the estimate: 15%; at least 11-fold (1.04 log units) between middle value and limit.
By their numbers in this assay, from the lowest: compound 3; then compound 1; then compound 2. At a limit, above all of these: compound 4.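

In this assay compound 4 gives > 100000 nM, a limit and not a number. The 1,3-thiazol-5-yl and pyridazin-3-yl groups have the same count of hetero atoms and of hydrogen-bond acceptors, yet the change on this carbonyl carbon gives an at least 52-fold higher number from compound 3 to compound 4 (1.72 log units; beyond the scatter), so those counts alone do not set the number here. Pyridazin-3-yl also fares worse than the other two six-membered rings, with an at least 2.8-fold higher number from compound 2 to compound 4 (0.45 log units; beyond the scatter) and an at least 17-fold higher number from compound 1 to compound 4 (1.24 log units; beyond the scatter). From the compounds shown here alone, it remains open whether the five-membered ring or its sulfur favours compound 3, a question that a furan-2-yl or thiophen-2-yl group could address. Going by these compounds, how far compound 4 really lies past its limit also stays unknown.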